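This account rests on a few compounds, and the source may have more. Where it says the series, first, only, none or still open, it means among the compounds named here.

Measured so far:
compound 1 `CCN(Cc1ccccc1)C(=O)c1nc(-c2ccc(Cl)cc2)c2ccccc2n1` — 0.762 nM
compound 2 `CCN(Cc1ccc(C)cc1)C(=O)c1nc(-c2ccccc2)c2ccccc2n1` — 2.57 nM
compound 3 `CN(Cc1ccccc1)C(=O)c1nc(-c2ccccc2)c2ccccc2n1` — 3.99 nM

In an assay on cell membranes from kidney for displacement of a labelled ligand from Translocator protein (Rattus norvegicus) (on this read-out higher numbers stand for weaker inhibition and lower numbers for stronger inhibition), compound 3 gives the highest of the three numbers. Its nearest neighbour is compound 2, whose number lies within the scatter of it, so the two cannot be told apart; compound 1 lies further off, with a lower number beyond the scatter. Compound 4 `CN(Cc1ccccc1)C(=O)c1nc(-c2ccc(Cl)cc2)c2ccccc2n1` has not been measured. It differs from compound 3 by chloro in place of hydrogen on an aromatic carbon, para to a large group. Among the compounds with values here, no measured pair isolates this change. Compound 1, which carries the same chloro group, gives 0.762 nM, so a downward step of moderate size is expected. Compound 4 is estimated at 1.5 nM, within 0.5 nM to 4.5 nM. The expected step is a 2.7-fold lower number from compound 3 to compound 4 (0.42 log units; beyond the scatter).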

Compound 4, inhibition constant: 6.12 nM
Beside the measured number, compound 4's estimate is 4.1-fold (0.61 log units) below it; measured number above the stated range.
By their numbers in this assay, from the lowest: compound 1; then compounds 2, 3 and 4 (each within the scatter of the next, the first and the last beyond it).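

In this assay, putting chloro in place of hydrogen on the aromatic carbon gives a 1.5-fold higher number from compound 3 to compound 4 (0.19 log units; within the scatter) and so no readable change with the shorter amide chain in place. The change at the amide chain instead gives an 8.0-fold higher number from compound 1 to compound 4 (0.90 log units; beyond the scatter) with the 4-chlorophenyl group held fixed, so the low number of compound 1 does not follow from chloro alone. No evidence at hand accounts for this result. The compounds shown leave open whether chloro has any effect with the longer chain of compound 1. They also leave open how a methoxy group at this ring position or a propyl chain on the amide nitrogen would read.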